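This account rests on a few compounds, and the source may have more. Where it says the series, first, only, none or still open, it means among the compounds named here.

In an assay on membranes from HEK293 cells for displacement of a labelled ligand from adenosine receptor A2b (Homo sapiens), read by scintillation counting, with a stated time of 30 min (on this read-out higher numbers stand for weaker inhibition and lower numbers for stronger inhibition), two compounds have been measured. Compound 1 `CC1=C(C(=O)OCC2CCC2)C(c2ccco2)NC(=O)N1` gives 561 nM. Compound 2 `CC1=C(C(=O)OC2CCC2)C(c2cccs2)NC(=O)N1` gives 1090 nM, the highest of the two numbers, though its gap to compound 1 lies within the usual scatter, so neither can be called the stronger binder on this evidence.

Compound 3 `CC1=C(C(=O)OCC2CCC2)C(c2cccs2)NC(=O)N1` is not yet measured. Relative to compound 2, the change is cyclobutylmethyl in place of cyclobutyl on an oxygen next to a carbonyl group. Within the data shown here, no step between measured compounds isolates this change, so its effect is not known from the data. Compound 1, which also carries cyclobutylmethyl on that oxygen, gives 561 nM, which is the only pointer available. On that basis the step from compound 2 to compound 3 is expected to be small, a 1.7-fold lower number from compound 2 to compound 3 (0.22 log units; within the scatter), and not clearly beyond the scatter. Compound 3 is expected to give about 650 nM in this assay, with a plausible range from 250 nM to 1700 nM.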

Compound 3, inhibition constant: 2840 nM
Compound 3: the middle estimate sits 4.4-fold (0.64 log units) below what was measured; measured number above the stated range.
By their numbers in this assay, from the lowest: compounds 1 and 2 (each within the scatter of the next); then compound 3.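

In this assay, the oxygen next to a carbonyl group now has a step of its own: with thiophen-2-yl held fixed, cyclobutylmethyl in place of cyclobutyl gives a 2.6-fold higher number from compound 2 to compound 3 (0.42 log units; beyond the scatter). The saturated ring carbon also has its first step: with cyclobutylmethyl held fixed, thiophen-2-yl in place of furan-2-yl gives a 5.1-fold higher number from compound 1 to compound 3 (0.70 log units; beyond the scatter), so both places register in this read-out, which compound 1 and compound 2, differing in both at once, could not show. Nothing among the data given accounts for the direction or size of either step.

The compounds shown hold the cyclobutyl to cyclobutylmethyl step only with thiophen-2-yl, so its size with furan-2-yl remains open. Also open, from the compounds shown here alone, is how a phenyl ring on the saturated ring carbon, or a longer chain on the oxygen, would read.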